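Fluoromethyl in Place of Cyano on a Four-Carbon Chain

This account rests on a few compounds, and the source may have more. Where it says the series, first, only, none or still open, it means among the compounds named here.

Compound 3 `N#CCCCn1c(Cn2c(=O)n(C3CC3)c3ccncc32)cc2cc(Cl)ccc21` is tested in an ADME assay on HeLa cells (Homo sapiens) for cytotoxicity, read by ATP content, with a stated time of 3 days; on this read-out higher numbers stand for lower toxicity in this test and lower numbers for higher toxicity in this test. Its value there is a limit of the assay rather than a number: compound 3 gives > 50000 nM. Compound 1 `O=C(O)CCCn1c(Cn2c(=O)n(C3CC3)c3ccncc32)cc2cc(Cl)ccc21` likewise gives only a limit, > 50000 nM. Compound 2 `O=c1n(Cc2cc3cc(Cl)ccc3n2CCCCO)c2cnccc2n1C1CC1` also gives only a limit, > 50000 nM. Together these three make up (the limit of > 50000 nM in this assay, at which 3 of the 3 values shown sit), so compound 3 stands level with the other two. Compound 4 `O=c1n(Cc2cc3cc(Cl)ccc3n2CCCCF)c2cnccc2n1C1CC1` differs from compound 3 by fluoromethyl in place of cyano on a saturated chain carbon, three bonds along the chain from an aromatic nitrogen. Going by the values given here, the steps that bear on this change, a step that the two limits leave unreadable from compound 1 to compound 3, a step that the two limits leave unreadable from compound 2 to compound 3 and a step that the two limits leave unreadable from compound 1 to compound 2, all stay unreadable, since each ends at the limit. No step beyond the scatter is therefore expected, a number no higher from compound 3 to compound 4 (the limit leaves the size open). Compound 4 is estimated at 50000 nM, between 20000 nM and 150000 nM, most likely again reported only as a limit.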

Compound 4, half-maximal cytotoxic concentration: > 50000 nM
Compound 4: a limit, no number (the forecaster's own chance of this, stated with the estimate: 80%); the middle value lies on the limit itself.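

In this assay compound 4 gives > 50000 nM, a limit and not a number, so its steps from compound 1, compound 2 and compound 3 cannot be read. Whether these four chain ends differ at all in this test stays open: the limit of > 50000 nM in this assay, at which 4 of the 4 values shown sit.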